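Working notes: 6-fluoropyridin-3-yl exchange on compound 3

This account rests on a few compounds, and the source may have more. Where it says the series, first, only, none or still open, it means among the compounds named here.

compound 1 `COc1ccc(C(=O)/C=C/c2ccccc2-c2ccc(F)cc2)cc1OC` gives 8300 nM
compound 2 `COc1ccc(C(=O)/C=C/c2ccccc2-c2ccc(F)nc2)cc1OC` gives 15000 nM
compound 3 `COc1cc(C(=O)/C=C/c2ccccc2-c2ccc(F)cc2)ccc1O` gives 4200 nM

In a functional assay on SW480 cells (Homo sapiens) for antiproliferative activity, read by sulforhodamine B assay, with a stated time of 48 h (on this read-out lower numbers stand for stronger inhibition and higher numbers for weaker inhibition), the two lowest numbers cannot be separated, with a 2.0-fold lower number from compound 1 to compound 3 (0.30 log units; within the scatter) between them, while compound 2 lies beyond the scatter from compound 3, at a higher number. The change to compound 4 `COc1cc(C(=O)/C=C/c2ccccc2-c2ccc(F)nc2)ccc1O` is 6-fluoropyridin-3-yl in place of 4-fluorophenyl on an aromatic carbon and the rest of the structure stays the same. Within the data shown here, only one measured step makes this same exchange, namely a 1.8-fold higher number from compound 1 to compound 2 (0.26 log units; within the scatter) and it sets the expected size. A step of like size toward a higher number, not clearly beyond the scatter, is expected, with a 1.8-fold higher number from compound 3 to compound 4 (0.25 log units; within the scatter) as the estimate. Compound 4 is estimated at 7500 nM with an expected range from 3500 nM to 15000 nM.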

Compound 4, half-maximal inhibitory concentration: 8500 nM
Compound 4: the middle estimate sits 1.1-fold (0.05 log units) below what was measured; measured number inside the range.
By their numbers in this assay, from the lowest: compounds 3, 1, 4 and 2 (each within the scatter of the next, the first and the last beyond it).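

Set on the second core, 6-fluoropyridin-3-yl in place of 4-fluorophenyl gives a 2.0-fold higher number from compound 3 to compound 4 (0.31 log units; beyond the scatter), and the size of this exchange holds across both cores: the same change on two cores in this assay, a 1.8-fold higher number (0.26 log units; within the scatter) from compound 1 to compound 2 and a 2.0-fold higher number (0.31 log units; beyond the scatter) from compound 3 to compound 4, 1.1-fold (0.05 log units) apart, within the scatter of two such steps

Hydrogen in place of methyl on the oxygen gives a 1.8-fold lower number from compound 2 to compound 4 (0.25 log units; within the scatter) with 6-fluoropyridin-3-yl present, so across these four compounds each change reads much the same whichever form the other place takes: the same change on two cores in this assay, a 2.0-fold lower number (0.30 log units; within the scatter) from compound 1 to compound 3 and a 1.8-fold lower number (0.25 log units; within the scatter) from compound 2 to compound 4, 1.1-fold (0.05 log units) apart, within the scatter of two such steps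

Open, from the compounds shown here alone, is how a ring carrying an amine or a carboxylic acid in place of the fluorine would read at this place. Also open, going by these compounds, is whether the step holds for a pyridinyl ring without fluorine.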